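Quinoline–triazolothiadiazole series: swapping the indole for fluorophenyl

The source may hold more compounds than are shown below. What is called first, only, known or untested is meant among the compounds shown, and "the series" means these compounds.

Compound 1 `COc1ccc2c(OCc3nnc4sc(-c5cc6ccccc6n5C)nn34)ccnc2c1` is the reference point of this set. In a functional assay on EBC-1 cells (Homo sapiens) for antiproliferative activity, with a stated time of 72 h (a lower number here means a stronger inhibitor, a higher number a weaker inhibitor), compound 1 gives 149 nM. Compound 3 `COc1ccc2[nH]c(-c3nn4c(COc5ccnc6cc(OC)ccc56)nnc4s3)cc2c1`, which carries a 5-methoxy-1H-indol-2-yl in place of the 1-methyl-1H-indol-2-yl, gives 85.6 nM in this assay; the step of a 1.7-fold lower number from compound 1 to compound 3 (0.24 log units; within the scatter) does not separate the two beyond the scatter. Compound 2 `COc1ccc2c(OCc3nnc4sc(-c5cc6cc(F)ccc6[nH]5)nn34)ccnc2c1` has no result in this assay ("not determined" (no result reported)). Of the two numbers available, compound 1 stands at the upper one, but only within scatter of compound 3.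

Compound 4 `COc1ccc2c(OCc3nnc4sc(-c5cccc(F)c5)nn34)ccnc2c1` is the next entry. Relative to compound 1 the change is 3-fluorophenyl in place of 1-methyl-1H-indol-2-yl on an aromatic carbon. Among the compounds with values here, the single measured step, from compound 1 to compound 3, exchanges one indole for another and so only weakly bears on the loss of the bicycle; it was small. Within the data shown here, no measured step covers removal of the indole itself, so any expectation rests on the absence of a comparable change. A moderate rise in the number is expected for compound 4, a step of a 2.0-fold higher number from compound 1 to compound 4 (0.30 log units; within the scatter) that may still fall within the scatter. For compound 4 the expected value in this assay is 300 nM, with a range from 90 nM to 1000 nM.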

Compound 4, half-maximal inhibitory concentration: 504 nM
For compound 4 the middle estimate is 1.7-fold (0.23 log units) below the measured one; low and high end bracket the measured number.
By their numbers in this assay, from the lowest: compounds 3 and 1 (each within the scatter of the next); then compound 4.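

In this assay, within the data shown here, the step of a 3.4-fold higher number from compound 1 to compound 4 (0.53 log units; beyond the scatter) and the step of a 5.9-fold higher number from compound 3 to compound 4 (0.77 log units; beyond the scatter) are the first in this set to lie beyond the scatter, though both are modest. On this aromatic carbon, next to the ring sulfur and the ring nitrogen, the two indoles stay within the scatter of each other, while 3-fluorophenyl gives the highest number of the three, so the change from an indole to this single ring is not neutral. Nothing available accounts for this rise.

The compounds shown do not separate the loss of the indole from the presence of the fluorine. An unsubstituted phenyl, or a phenyl carrying an amine or a carboxylic acid, would test whether any single ring at this place gives a similar rise.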